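A few compounds are considered here, and "the series" means these few. Any claim that something is new, unique, unknown or untested is made for them only; others in the source may bear on it.

Working notes on a small amide series. Compound 1 `Cc1cc(NC(=O)c2cccc(C(F)(F)F)c2)ccc1NS(=O)(=O)C(F)(F)F` and compound 2 `Cc1cc(NC(=O)c2cc(C(F)(F)F)cc(C(F)(F)F)c2)ccc1NS(=O)(=O)C(F)(F)F` share one core; compound 3 `CCS(=O)(=O)Nc1ccc(NC(=O)c2cccc(C(F)(F)F)c2)cc1F` and compound 4 `CCS(=O)(=O)Nc1ccc(NC(=O)c2cc(C(F)(F)F)cc(C(F)(F)F)c2)cc1F` share another. The difference between the two cores is not broken down here. In an ADME assay on RAW264.7 cells (Mus musculus) for cytotoxicity, read by MTT assay, with a stated time of 48 h (a lower number here means a stronger inhibitor, a higher number a weaker inhibitor), compound 1 gives 8720 nM, compound 2 gives 40700 nM and compound 3 gives 119000 nM; compound 3 stands highest of the three measured compounds, and compound 4 has not yet been measured.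

Within the first core, the change is trifluoromethyl in place of hydrogen on an aromatic carbon, and the step is a 4.7-fold higher number from compound 1 to compound 2 (0.67 log units; beyond the scatter). The change from compound 3 to compound 4 is trifluoromethyl in place of hydrogen on an aromatic carbon; its place reads the same as the earlier one, so it is counted as the same change on a different core. Among the compounds with values here, only one measured instance of this change exists, so the expectation rests on that single step in this assay together with the value of compound 3.

Compound 4 is expected to move by a 2.9-fold higher number from compound 3 to compound 4 (0.47 log units; beyond the scatter), since compound 1 to compound 2 gave a 4.7-fold higher number from compound 1 to compound 2 (0.67 log units; beyond the scatter) and compound 3 already stands at 119000 nM. For compound 4 the estimate is 350000 nM, with a range from 120000 nM to 900000 nM.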

Compound 4, half-maximal inhibitory concentration: > 250000 nM
Compound 4 was reported as a limit; the forecaster's own chance of this, stated with the estimate: 35%; the middle value is on the limit's open side.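

In this assay compound 4 gives > 250000 nM, which is a limit of the assay and not a number. Trifluoromethyl in place of hydrogen on an aromatic carbon gives an at least 2.1-fold higher number from compound 3 to compound 4 (0.32 log units; beyond the scatter), so the number moves the same way on this core as in the earlier step, a 4.7-fold higher number from compound 1 to compound 2 (0.67 log units; beyond the scatter). This shows that the direction of the change carries from one core to the other in these two pairs, but not that its size does: the same change on two cores in this assay, a 4.7-fold higher number (0.67 log units; beyond the scatter) from compound 1 to compound 2 and an at least 2.1-fold higher number (0.32 log units; beyond the scatter) from compound 3 to compound 4; the limit leaves it open whether they differ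

Trifluoromethyl is the only group shown entering at this place, so it remains open whether an amine, a nitrile or a carboxylic acid there would move the number in the same direction. The reading also rests on two pairs in a single assay, which leaves open how the change behaves on any core beyond those of compound 1 and compound 3.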